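From Pentyl to Cyclooctyl on a Shared Core

The source may report more compounds than this note shows. Statements on the series, on what has been measured and on what is new or still open speak of the compounds shown alone.

In a functional assay on PC-3 cells (Homo sapiens) for cytotoxicity, read by WST assay, with a stated time of 72 h (on this read-out lower numbers stand for stronger inhibition and higher numbers for weaker inhibition), compound 1 `O=C1Nc2c(ccc(F)c2F)C1(c1ccc(O)cc1)c1ccc(F)cc1` with 4-fluorophenyl gives 8.6 nM as its value. Compound 2 `O=C1Nc2c(ccc(F)c2F)C1(c1ccncc1)c1ccc(O)cc1` with pyridin-4-yl gives 110 nM as its value, and compound 3 `CCCCCC1(c2ccc(O)cc2)C(=O)Nc2c1ccc(F)c2F` with pentyl gives 1.1 nM, the lowest number of the three. Compound 4 `O=C1Nc2c(ccc(F)c2F)C1(c1ccc(O)cc1)C1CCCCCCC1` keeps the shared core but carries cyclooctyl in place of pentyl on a saturated ring carbon.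

All three measured steps concern this same carbon. Swapping 4-fluorophenyl for pyridin-4-yl gives a 13-fold higher number from compound 1 to compound 2 (1.11 log units; beyond the scatter), while pentyl gives a 7.8-fold lower number from compound 1 to compound 3 (0.89 log units; beyond the scatter) against 4-fluorophenyl and a 100-fold lower number from compound 2 to compound 3 (2.00 log units; beyond the scatter) against pyridin-4-yl. Going by the values given here, the number therefore responds strongly to this substituent, but no measured compound carries a saturated ring here. Cyclooctyl, like pentyl, is made of carbon only, so in this assay a small step is expected, slightly upward and not clearly beyond the scatter. The estimated change is a 1.8-fold higher number from compound 3 to compound 4 (0.26 log units; within the scatter) and would stay within that scatter. For compound 4 the expected value is 2 nM, with an estimated range from 0.5 nM to 10 nM.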

Compound 4, half-maximal inhibitory concentration: > 1000 nM
Compound 4: a limit, no number; the forecaster's own chance of this, stated with the estimate: 3%; at least 500-fold (2.69 log units) between middle value and limit.
By their numbers in this assay, from the lowest: compound 3; then compound 1; then compound 2. At a limit, above all of these: compound 4.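

Compound 4 gives no number, only a limit of the assay: the limit of > 1000 nM in this assay, at which 1 of the 4 values shown sits.

Even so, the change at this saturated ring carbon reaches far: an at least 900-fold higher number from compound 3 to compound 4 (2.95 log units; beyond the scatter). Until now, the carbon-only pentyl had given the lowest number and the rise had come with pyridin-4-yl, but a group made of carbon alone now moves the read-out the other way, with an at least 9.0-fold higher number from compound 2 to compound 4 (0.95 log units; beyond the scatter) and an at least 110-fold higher number from compound 1 to compound 4 (2.06 log units; beyond the scatter). At this position, then, having carbon only does not keep the number low, and cyclooctyl cannot stand in for pentyl.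

On these data alone, the true size of these steps stays open behind the limit. The compounds shown also leave open whether a smaller ring such as cyclopentyl, or a longer chain such as octyl, would stay close to compound 3 or rise towards compound 4.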